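Nitrophenyl dienones: chloro to dimethylamino on the second aryl

The compounds below may be only part of what the source reports. "The series", "measured", "known", "first", "only" and "open" are said of these compounds alone.

Measured compounds in a functional assay on MOLT-4 cells (Homo sapiens) for cytotoxicity, with a stated time of 72 h; on this read-out higher numbers stand for weaker inhibition and lower numbers for stronger inhibition:
Compound 1 `O=C1/C(=C/c2ccc(Cl)cc2)CCC/C1=C\c1ccc([N+](=O)[O-])cc1` gives 9120 nM.
Compound 2 `CN(C)c1ccc(/C=C2\CCC/C(=C\c3ccc([N+](=O)[O-])cc3)C2=O)cc1` gives > 500000 nM, which is a limit of the assay and not a number.
Compound 3 `O=C1/C(=C/c2ccc(Cl)cc2)CCC/C1=C\c1cccc([N+](=O)[O-])c1` gives 2020 nM.

Compound 3 holds the lowest of the two numbers shown, with compound 1 next; the difference between the two cores of compound 1 and compound 3 is not broken down here. Compound 2 sits at the limit of > 500000 nM in this assay, at which 1 of the 3 values shown sits.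

The one measured step, an at least 54-fold higher number from compound 1 to compound 2 (1.73 log units; beyond the scatter), comes from a single change:
dimethylamino in place of chloro on an aromatic carbon

The same change is now made from compound 3 to compound 4 `CN(C)c1ccc(/C=C2\CCC/C(=C\c3cccc([N+](=O)[O-])c3)C2=O)cc1`, which is not yet measured:
dimethylamino in place of chloro on an aromatic carbon

The place lines of the two changes read alike word for word, so the step from compound 3 to compound 4 is taken as the same change on a core that differs only in the way the two aryl groups are joined to it. Because an at least 54-fold higher number from compound 1 to compound 2 (1.73 log units; beyond the scatter) is large and runs out to a limit, a step of similar size, a 74-fold higher number from compound 3 to compound 4 (1.87 log units; beyond the scatter), is expected here. Compound 4 is therefore estimated at 150000 nM in this assay, with a range from 30000 nM to 600000 nM, and with a fair chance that the assay again returns only a limit rather than a number.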

Compound 4, half-maximal inhibitory concentration: 10900 nM
Compound 4: middle estimate off by 14-fold (1.14 log units), on the high side; the whole stated range lies above it.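

In this assay, the change from 4-chlorophenyl to 4-(dimethylamino)phenyl keeps its direction on the second core, with a 5.4-fold higher number from compound 3 to compound 4 (0.73 log units; beyond the scatter), but it does not keep its size: the same change on two cores in this assay, an at least 54-fold higher number (1.73 log units; beyond the scatter) from compound 1 to compound 2 and a 5.4-fold higher number (0.73 log units; beyond the scatter) from compound 3 to compound 4, at least 10-fold (1.00 log units) apart, beyond the scatter of two such steps

With dimethylamino in place on both compounds, the swap of 4-nitrophenyl for 3-nitrophenyl gives an at least 45-fold lower number from compound 2 to compound 4 (1.66 log units; beyond the scatter), so in this pair the nitro placement decides how much activity survives in this assay.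

Compound 2 gives > 500000 nM, which is a limit of the assay and not a number, so the true size of the first step stays unknown, and the comparison shows only that the change cannot be carried between these cores at a fixed size, not why the two steps part: the limit of > 500000 nM in this assay, at which 1 of the 4 values shown sits.

The compounds shown leave open whether the wide step belongs to 4-nitrophenyl alone or would also appear with another group on that aryl ring, such as a nitrile or a methoxy group. On these data alone, it also remains open whether a simple amino group or a morpholine in place of dimethylamino would follow the smaller step, the larger one, or neither on these two cores.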